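Swapping hydroxy for methylamino on a strong antiproliferative compound

The source may hold more compounds than are shown below. What is called first, only, known or untested is meant among the compounds shown, and "the series" means these compounds.

In a functional assay on A549 cells (Homo sapiens) for antiproliferative activity, read by MTT assay, with a stated time of 48 h (on this read-out higher numbers stand for weaker inhibition and lower numbers for stronger inhibition), compound 1 (`CNCC(=O)Nc1cc(OC)ccc1C(=O)c1cc(OC)c(OC)c(OC)c1`) gives 610 nM and compound 2 (`C=C(c1ccc(OC)cc1NC(=O)CO)c1ccc(OC)c2c1OC(C)(C)C=C2`) gives 40 nM as its value. Compound 2 therefore holds the lower of the two numbers, which marks it as the stronger inhibitor, and the gap lies beyond the usual scatter of repeated measurements.

Compound 3 (`C=C(c1ccc(OC)cc1NC(=O)CNC)c1ccc(OC)c2c1OC(C)(C)C=C2`) keeps the core of compound 2 and changes a single group, with methylamino in place of hydroxy on a saturated chain carbon bound to a carbonyl carbon.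

Within the data shown here, no measured pair shows this swap on its own, so the size of the step in this assay has to be judged. Among the measured compounds shown here, the only hint is compound 1, which also carries methylamino and gives 610 nM on a different core, so its number cannot separate the group from the core. A modest move toward weaker inhibition is expected, close to the edge of the scatter (a 2.0-fold higher number from compound 2 to compound 3 (0.30 log units; within the scatter)). Compound 3 is estimated to give 80 nM (20 nM to 300 nM).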

Compound 3, half-maximal inhibitory concentration: 150 nM
Beside the measured number, compound 3's estimate is 1.9-fold (0.27 log units) below it, and the stated range covers the measured number.
By their numbers in this assay, from the lowest: compound 2; then compound 3; then compound 1.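

In this assay, methylamino in place of hydroxy on a saturated chain carbon bound to a carbonyl carbon now has a size of its own on a single core: the swap gives a 3.8-fold higher number from compound 2 to compound 3 (0.57 log units; beyond the scatter) and so moves the number past the usual scatter, though only modestly. This position is therefore not indifferent to the group it carries, even though hydroxy and methylamino match in their counts of hydrogen-bond donors and acceptors and neither bears a net charge, so those counts alone do not settle the number here. Nothing in the data at hand explains why this swap moves the number.

The compounds shown leave open how an unsubstituted amino group, a dimethylamino group or a carboxylic acid would compare with hydroxy and methylamino on this saturated chain carbon bound to a carbonyl carbon. They also leave open how a longer chain would fare here, and whether the same swap would bring a step of similar size on the core of compound 1.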